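Swapping methyl for fluoro on the aromatic ring

This account rests on a few compounds, and the source may have more. Where it says the series, first, only, none or still open, it means among the compounds named here.

Measured so far:
Compound 1 `Cc1ccc2c(c1)/C(=N/NC(=S)NO)C(=O)N2CN(C)C` gives 651000 nM
Compound 2 `CCn1cc(C(=O)O)c(=O)c2cc(F)c(N3CCN(CN4C(=O)/C(=N\NC(=S)NO)c5cc(C)ccc54)C(C)C3)c(F)c21` gives 244000 nM
Compound 3 `CCn1cc(C(=O)O)c(=O)c2cc(F)c(N3CCN(CN4C(=O)/C(=N\NC(=S)NOC)c5cc(C)ccc54)C(C)C3)c(F)c21` gives 156000 nM

In an ADME assay on MT4 cells (Homo sapiens) for cytotoxicity, read by spectrophotometry, with a stated time of 5 days (a higher number here means that more compound is tolerated, a lower number that less compound is tolerated), compound 3 stands within the scatter of compound 2, and both numbers lie well under that of compound 1. Compound 4 `CCn1cc(C(=O)O)c(=O)c2cc(F)c(N3CCN(CN4C(=O)/C(=N\NC(=S)NOC)c5cc(F)ccc54)C(C)C3)c(F)c21` differs from compound 3 in one group (fluoro in place of methyl on an aromatic carbon): fluoro in place of methyl on an aromatic carbon. For the measured compounds named here, no measured step makes this swap. The nearest guide is a 1.6-fold lower number from compound 2 to compound 3 (0.19 log units; within the scatter) with methyl in place of hydrogen on an oxygen, a change elsewhere in the molecule. The step expected in this assay is none beyond the scatter, estimated as a 1.0-fold higher number from compound 3 to compound 4 (0.01 log units; within the scatter) for this swap. Compound 4 is estimated at 160000 nM with an expected range of 80000 nM to 320000 nM in this measurement.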

Compound 4, half-maximal cytotoxic concentration: 178000 nM
Compound 4: the middle estimate sits 1.1-fold (0.05 log units) below what was measured, and the stated range covers the measured number.
By their numbers in this assay, from the lowest: compounds 3, 4 and 2 (each within the scatter of the next); then compound 1.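

In this assay, putting fluoro in place of methyl on this aromatic carbon gives a 1.1-fold higher number from compound 3 to compound 4 (0.06 log units; within the scatter), so the two groups cannot be told apart here. Compound 1, compound 2 and compound 3 all carry methyl at this carbon, so they gave no reading of a swap at this position. No measured evidence accounts for this result. Going by these compounds, whether chlorine, methoxy or an amine on this carbon would also stay within the scatter remains open. So does whether fluoro would give the same result with the hydrogen of compound 2 on the oxygen.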